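The compounds below may be only part of what the source reports. "The series", "measured", "known", "first", "only" and "open" are said of these compounds alone.

For the measured compounds named here, in a functional assay on cells (T-cell, Homo sapiens) for inhibition (a lower number here means a stronger inhibitor, a higher number a weaker inhibitor), compound 2 `COc1ccc(-c2cnc3nc(N)nc(N4CCN(C(=O)c5ccccc5)CC4)c3n2)cc1OC` gives 400 nM, the only plain number among the values shown. Compound 1 `CC(C)Oc1nc(N)nc2ncc(-c3ccc(C#N)cc3)nc12` reaches only a limit of the assay in this assay, > 10000 nM. Compound 3 `COc1ccc(-c2cnc3nc(N)nc(N4CCN(C(=O)COc5ccc(Cl)cc5)CC4)c3n2)cc1OC` differs from compound 2 in one place: (4-chlorophenoxy)methyl in place of phenyl on a carbonyl carbon. Going by the values given here, no measured pair of compounds shares this change, so there is no measured step to lean on. With nothing to point to, the expected step of no change at the digits printed from compound 2 to compound 3 (within the scatter) is none beyond the usual scatter, in no particular direction. Compound 3 is therefore estimated to come out near 400 nM, likely between 100 nM and 1600 nM.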

Compound 3, half-maximal inhibitory concentration: 0.5 nM
Compound 3: the middle estimate sits 800-fold (2.90 log units) above what was measured; measured number outside the range, below it.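

The group on this carbonyl carbon is far from a neutral choice: in this assay, (4-chlorophenoxy)methyl in place of phenyl gives an 800-fold lower number from compound 2 to compound 3 (2.90 log units; beyond the scatter). This single place therefore has a strong hold on inhibition, at least for this pair. Nothing measured here explains why the step is so large.

On these data alone, it remains open which part of the new group carries the step: the chlorine, the oxygen or the extra carbon. Whether a group holding an amine or a carboxylic acid, or a longer chain, would keep this strength is also unknown.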